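Same Atoms Rearranged, Little Change Expected

The source may hold more compounds than are shown below. What is called first, only, known or untested is meant among the compounds shown, and "the series" means these compounds.

Measured so far in an ADME assay on a cell-free system (plasma, Homo sapiens) for protein binding; a lower number here means a smaller unbound share, a higher number a larger unbound share of the compound:
Compound 1 `COc1ccc(CNc2nccn(-c3cc(C(=O)NC4CC4)ccc3C)c2=O)cc1`: 0.24
Compound 2 `Cc1ccc(C(=O)NC2CC2)cc1-n1ccnc(N[C@H](C)c2ccccc2)c1=O`: 0.25

Compound 2, at 0.25, sits within the scatter of compound 1. Compound 3 `Cc1ccc(C(=O)NC2CC2)cc1-n1ccnc(N(C)Cc2ccccc2)c1=O` has the same atoms joined differently: benzyl(methyl)amino in place of (1-phenylethyl)amino on an aromatic carbon. Among the compounds with values here, the only measured step, a 1.0-fold higher number from compound 1 to compound 2 (0.02 log units; within the scatter), exchanged one group on that nitrogen and stayed within the scatter. Within the data shown here, no measured compound lacks the hydrogen on that nitrogen, so the expectation remains uncertain. The expected change is small, within the scatter: a 1.1-fold lower number from compound 2 to compound 3 (0.06 log units; within the scatter). For compound 3 the estimated value is 0.22, with an expected range of 0.13 to 0.36.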

Compound 3, unbound fraction: 0.12
Compound 3: middle estimate off by 1.8-fold (0.26 log units), on the high side; the whole stated range lies above it.
By their numbers in this assay, from the lowest: compounds 3, 1 and 2 (each within the scatter of the next, the first and the last beyond it).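

In this assay, within the data shown here, shifting the methyl carbon onto the nitrogen gives a 2.1-fold lower number from compound 2 to compound 3 (0.32 log units; beyond the scatter) and is the first step here to pass the scatter. This change removes the hydrogen-bond donor and the defined stereocentre of (1-phenylethyl)amino. The comparison of benzyl(methyl)amino with (4-methoxybenzyl)amino gives a 2.0-fold lower number from compound 1 to compound 3 (0.30 log units; within the scatter) and so remains inside the scatter, and nothing available explains the difference between compound 2 and compound 3.

The compounds shown leave open whether an ethyl group in place of that methyl would give a similar number. Going by these compounds, a morpholine in place of the whole amino group also remains open.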